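The source may hold more compounds than are shown below. What is called first, only, known or untested is meant among the compounds shown, and "the series" means these compounds.

Working notes on the series.

Among the measured compounds shown here, compound 2, `O=C(Nc1ccc(Cl)c(-c2nnc3c(Cl)cccn23)c1)c1ccccc1Cl`, holds the only numerical value in the set so far: in a functional assay on T47D cells (Homo sapiens) for antiproliferative activity, read by MTT assay, with a stated time of 72 h (a lower number here means a stronger inhibitor, a higher number a weaker inhibitor), compound 2 gives 83800 nM. Compound 1, `O=C(Nc1ccc(Cl)c(-c2nnc3c(Cl)cccn23)c1)c1c(F)cccc1Cl`, returns only a limit in this assay, > 100000 nM, and not a number; this is the limit described by the limit of > 100000 nM in this assay, at which 1 of the 2 values shown sits. For the measured compounds named here, the one measured step, hydrogen in place of fluoro on an aromatic carbon, is an at least 1.1-fold lower number from compound 1 to compound 2 (0.07 log units; that floor lies within the scatter), and it shows no change that can be separated from the scatter.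

Compound 3, `Cc1cc(Cl)ccc1C(=O)Nc1ccc(Cl)c(-c2nnc3c(Cl)cccn23)c1`, differs from compound 2 as follows: 4-chloro-2-methylphenyl in place of 2-chlorophenyl on a carbonyl carbon. Going by the values given here, this change sits on the carbonyl carbon and is of a different kind from the measured step, so no step among the measured compounds bears directly on it. Among the compounds with values here, the only evidence available is that the single aryl-ring edit seen so far, from compound 1 to compound 2, stayed within the scatter, and compound 2 itself lies close to the limit of this assay.

The expectation for compound 3 is therefore a step of a 1.0-fold higher number from compound 2 to compound 3 (0.01 log units; within the scatter), that is, no move beyond the scatter, with a real chance that only a limit is returned. Compound 3 is estimated at 85000 nM, with a range from 30000 nM to 250000 nM.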

Compound 3, half-maximal inhibitory concentration: > 100000 nM
Compound 3 ended at the assay's limit; the forecaster's own chance of this, stated with the estimate: 40%; middle value at least 1.1-fold (0.07 log units) from the limit.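

Replacing 2-chlorophenyl with 4-chloro-2-methylphenyl on a carbonyl carbon gives an at least 1.1-fold higher number from compound 2 to compound 3 (0.07 log units; that floor lies within the scatter), so this first change of the whole aryl group, like the fluoro edit before it, shows no move that can be separated from the scatter. The step linking compound 1 and compound 3 cannot be read, since each of the two gives only a limit and no number. The added methyl and the changed chlorine pattern therefore bring no gain that can be seen, and the aryl variants shown so far remain at the edge of what this assay can resolve: the limit of > 100000 nM in this assay, at which 2 of the 3 values shown sit.

Going by these compounds, it remains open whether any group on the carbonyl carbon can give a number clearly lower than that of compound 2, for instance a phenyl ring carrying a dimethylamino group or a carboxylic acid, or a morpholine in place of the aryl ring. The shared core is the same in all three compounds, so the effect in this assay of a change there, such as a methoxy group in place of a chlorine, is also unknown.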